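This account rests on a few compounds, and the source may have more. Where it says the series, first, only, none or still open, it means among the compounds named here.

In a functional assay on brain (Rattus norvegicus, strain Wistar) for inhibition (on this read-out higher numbers stand for weaker inhibition and lower numbers for stronger inhibition), compound 1 (`COc1ccc(-c2c(C)[nH]c(=O)n2C)cc1`) gives 147000 nM and compound 2 (`Cc1[nH]c(=O)n(C)c1-c1ccc(CC(C)C)cc1`) gives 7800 nM as the lower of the two numbers. Compound 3 (`CCCCCCc1ccc(-c2c(C)[nH]c(=O)n2C)cc1`) has pentyl in place of isopropyl on a saturated chain carbon bound to an aromatic carbon. Among the measured compounds shown here, only one measured step bears on this change, the large 19-fold lower number from compound 1 to compound 2 (1.28 log units; beyond the scatter) for isobutyl in place of methoxy on an aromatic carbon, and it lies at a different place. In this assay a smaller step in the same direction is therefore expected (a 2.2-fold lower number from compound 2 to compound 3 (0.35 log units; beyond the scatter)). Compound 3 is estimated at 3500 nM (range 900 nM to 14000 nM).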

Compound 3, half-maximal inhibitory concentration: 9000 nM
The estimate for compound 3 lay 2.6-fold (0.41 log units) below the measured number, and the stated range covers the measured number.
By their numbers in this assay, from the lowest: compounds 2 and 3 (each within the scatter of the next); then compound 1.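

In this assay, pentyl in place of isopropyl on a saturated chain carbon bound to an aromatic carbon gives a 1.2-fold higher number from compound 2 to compound 3 (0.06 log units; within the scatter) and so shows no measurable effect of this change. The large step away from methoxy is still present with hexyl, at a 16-fold lower number from compound 1 to compound 3 (1.21 log units; beyond the scatter) in the same direction as with isobutyl. No evidence is available to explain this result.

The compounds shown leave open whether a longer chain would stay at this level. They also leave open how an amine or a carboxylic acid at this place would read out.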